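The source may report more compounds than this note shows. Statements on the series, on what has been measured and on what is new or still open speak of the compounds shown alone.

Compound 1 `CCCCC(CC)N(Cc1ccc(C(=O)NCCC(=O)O)cc1)C(=O)Nc1ccc(OC(F)(F)F)cc1` carries a 1-ethylpentyl group on the amide-type nitrogen, and in an in vitro assay on BHK cells for inhibition of Glucagon receptor (Homo sapiens) (a higher number here means a weaker inhibitor, a lower number a stronger inhibitor), compound 1 gives 141 nM. Compound 2 `COC1CCC(N(Cc2ccc(C(=O)NCCC(=O)O)cc2)C(=O)Nc2ccc(OC(F)(F)F)cc2)CC1` replaces that group with 4-methoxycyclohexyl. In this assay compound 2 reaches only a limit, > 10000 nM, so its true number is not known. Among the measured compounds shown here, the step of an at least 70-fold higher number from compound 1 to compound 2 (1.85 log units; beyond the scatter) is therefore only a lower bound, and one of the two values so far sits at the limit of > 10000 nM in this assay, at which 1 of the 2 values shown sits.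

Compound 3 `O=C(O)CCNC(=O)c1ccc(CN(C(=O)Nc2ccc(OC(F)(F)F)cc2)C2CCN(C(=O)C3CC3)CC2)cc1` is the next member: 1-(cyclopropylcarbonyl)piperidin-4-yl in place of 4-methoxycyclohexyl on an amide-type nitrogen. For the measured compounds named here, only one measured step bears on this change, the large loss an at least 70-fold higher number from compound 1 to compound 2 (1.85 log units; beyond the scatter), which shows that a six-membered saturated ring on this nitrogen is tolerated poorly compared with the branched chain of compound 1. Since compound 3 keeps a six-membered saturated ring at the same place, the expectation is that compound 3 stays weak, and the expected step of an at least 1.2-fold lower number from compound 2 to compound 3 (0.09 log units; that floor lies within the scatter) is small. Compound 3 is thus estimated at 8000 nM, within a range from 1500 nM to 30000 nM, with a fair chance that this assay again reports only a limit.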

Compound 3, half-maximal inhibitory concentration: 1980 nM
Compound 3: middle estimate off by 4.0-fold (0.61 log units), on the high side, within the range that was stated.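

In this assay the six-membered saturated rings on this amide-type nitrogen are not all equally poor: 1-(cyclopropylcarbonyl)piperidin-4-yl in place of 4-methoxycyclohexyl gives an at least 5.0-fold lower number from compound 2 to compound 3 (0.70 log units; beyond the scatter) and so separates the two rings beyond the scatter. The size of that step is only a floor, since compound 2 carries a limit and not a number: the limit of > 10000 nM in this assay, at which 1 of the 3 values shown sits. Even so, the gain does not bring the ring level with the branched chain, for 1-(cyclopropylcarbonyl)piperidin-4-yl in place of 1-ethylpentyl gives a 14-fold higher number from compound 1 to compound 3 (1.15 log units; beyond the scatter) and leaves 1-ethylpentyl the better of the three groups at this place.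

The compounds shown leave open whether the gain belongs to the ring nitrogen of the piperidine or to the cyclopropylcarbonyl on it, a question that a plain piperidin-4-yl or an acetyl on the same ring nitrogen would address. Also open, going by these compounds, is how a shorter or a longer branched chain than 1-ethylpentyl would compare with compound 1 on this nitrogen.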